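A few compounds are considered here, and "the series" means these few. Any claim that something is new, unique, unknown or untested is made for them only; others in the source may bear on it.

Of the compounds shown here, two built on one shared core have been measured in a functional assay on CCRF-CEM cells (Homo sapiens) for antiproliferative activity, with a stated time of 72 h; on this read-out lower numbers stand for stronger inhibition and higher numbers for weaker inhibition. Compound 1 `OC[C@H]1O[C@@H](n2cnc3c(NCc4ccc(F)cc4)ncnc32)[C@H](O)[C@@H]1O`, with fluoro on an aromatic carbon, gives 1250 nM, while compound 2 `OC[C@H]1O[C@@H](n2cnc3c(NCc4ccc(Cl)cc4)ncnc32)[C@H](O)[C@@H]1O`, with chloro at that place, gives 10200 nM. Going by the values given here, compound 2 therefore holds the higher of the two numbers, meaning the weaker inhibition, and compound 1 is its only neighbour.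

Compound 3 `Cc1cccc(CNc2ncnc3c2ncn3[C@@H]2O[C@H](CO)[C@@H](O)[C@H]2O)c1` differs from compound 2 as follows: 3-methylphenyl in place of 4-chlorophenyl on a saturated chain carbon bound to a nitrogen on an aromatic ring. In short, 3-methylphenyl stands in place of 4-chlorophenyl on a saturated chain carbon bound to a nitrogen on an aromatic ring.

Among the compounds with values here, no measured step involves a methyl group, so the evidence is indirect. Within the data shown here, the only guide is an 8.2-fold higher number from compound 1 to compound 2 (0.91 log units; beyond the scatter), a modest step beyond the scatter, which shows that exchanging one group on an aromatic carbon can move the number. Losing the chloro is therefore tentatively expected to bring a modest shift towards a lower number, somewhat smaller than that step. The expected change is a 2.9-fold lower number from compound 2 to compound 3 (0.46 log units; beyond the scatter). For compound 3, the estimated value is 3500 nM, with an expected range from 800 nM to 15000 nM.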

Compound 3, half-maximal inhibitory concentration: 19100 nM
Estimate against measurement, compound 3: 5.5-fold (0.74 log units) below; the measured number lies above the stated range.
By their numbers in this assay, from the lowest: compound 1; then compounds 2 and 3 (each within the scatter of the next).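

In this assay, 3-methylphenyl in place of 4-chlorophenyl on a saturated chain carbon bound to a nitrogen on an aromatic ring gives a 1.9-fold higher number from compound 2 to compound 3 (0.27 log units; within the scatter) and so does not separate these two groups on this read-out. Set against compound 1, the same group gives a 15-fold higher number from compound 1 to compound 3 (1.18 log units; beyond the scatter) and this large step, together with an 8.2-fold higher number from compound 1 to compound 2 (0.91 log units; beyond the scatter) as the earlier step, leaves 4-fluorophenyl as the one group of the three that stands apart, with the lowest number. Nothing measured here explains this difference.

Going from 4-chlorophenyl to 3-methylphenyl alters both the substituent and the number in the group's name at once, so the compounds shown cannot separate what the group itself contributes from what its location on the ring contributes. Going by these compounds, how a plain phenyl group, a methoxy group or a nitrile on that ring, or a longer chain between the ring and the nitrogen, would read remains open.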